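Ring-nitrogen substituent swaps: cytotoxicity notes on the shared core

The source may hold more compounds than are shown below. What is called first, only, known or untested is meant among the compounds shown, and "the series" means these compounds.

Measured so far:
compound 1 `CCCCNc1nc(N)nc2ccn(CC(=O)NC)c12` — > 24000 nM
compound 2 `CCCCNc1nc(N)nc2ccn(Cc3cn4ccccc4n3)c12` — > 24000 nM

In an ADME assay on HEK293 cells (Homo sapiens) for cytotoxicity, read by ATP content, with a stated time of 6 h (on this read-out higher numbers stand for lower toxicity in this test and lower numbers for higher toxicity in this test), compound 1 gives > 24000 nM, which is a limit of the assay and not a number. Compound 2 likewise gives > 24000 nM in this assay, again a limit. Both values therefore sit at the limit of > 24000 nM in this assay, at which 2 of the 2 values shown sit, so nothing distinguishes compound 1 from compound 2 on the numbers shown, and no measured step between compounds differing in one place is available.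

Compound 3 `CCCCNc1nc(N)nc2ccn(Cc3cccc(C)n3)c12` is not yet measured in this assay. It differs from compound 1 by 6-methylpyridin-2-yl in place of methylcarbamoyl on a saturated chain carbon bound to an aromatic nitrogen. Since compound 1 shows only the limit > 24000 nM, the expected step that the limit leaves unreadable from compound 1 to compound 3 is none beyond the scatter, with the result most likely reported again as a limit. For compound 3 the estimate in this assay is 30000 nM, with a range from 12000 nM to 70000 nM.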

Compound 3, half-maximal cytotoxic concentration: > 24000 nM
Compound 3 ended at the assay's limit; the forecaster's own chance of this, stated with the estimate: 80%; the middle value is on the limit's open side.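

In this assay compound 3 gives > 24000 nM which is a limit and not a number. Going by these compounds alone, no step from compound 1 to compound 3 can be read: the limit of > 24000 nM in this assay, at which 3 of the 3 values shown sit.

The compounds shown leave open where the half-maximal cytotoxic concentration of any of the three actually lies.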